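The source may hold more compounds than are shown below. What is called first, only, known or untested is meant among the compounds shown, and "the series" means these compounds.

Measured compounds:
compound 1, `COc1ccc(C[S+]([O-])c2ncccc2C(=O)Nc2ccncc2)c(OC)c1OC`: 116 h
compound 2, `COc1cc(OC)c(OC)cc1C[S+]([O-])c1ncccc1C(=O)Nc1ccncc1`: 0.14 h
compound 3, `COc1cc(OC)c(C[S+]([O-])c2ncccc2C(=O)Nc2ccncc2)c(OC)c1`: < 0.03 h

These three compounds share one core and differ only in how their three methoxy groups are arranged. In an ADME assay (a higher number here means that the compound lasts longer, a lower number that the compound disappears faster), compound 1 gives 116 h and compound 2 gives 0.14 h. For compound 3 the assay reports only a limit, < 0.03 h. Compound 3 therefore sits at the limit of < 0.03 h in this assay, at which 1 of the 3 values shown sits, the lowest reading this assay can give.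

Compound 4, `COc1cccc(OC)c1C[S+]([O-])c1ncccc1C(=O)Nc1ccncc1`, differs from compound 3 in one place: hydrogen in place of methoxy on an aromatic carbon. Among the measured compounds shown here, no measured pair isolates this change, so its effect is unknown. Because compound 3 stands at the limit of < 0.03 h in this assay, at which 1 of the 3 values shown sits, a step beyond the scatter in this assay is expected upward. Compound 4 is expected to give 0.3 h, within 0.03 h to 3 h. This estimate means an expected step of an at least 10-fold higher number from compound 3 to compound 4 (1.00 log units; beyond the scatter).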

Compound 4, half-life: 38.5 h
For compound 4 the middle estimate is 130-fold (2.11 log units) below the measured one; measured number outside the range, above it.
By their numbers in this assay, from the lowest: compound 2; then compound 4; then compound 1. At a limit, below all of these: compound 3.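

At this place on the aromatic ring, para to a large group, a single substitution has a very large effect in this assay: hydrogen in place of methoxy brings an at least 1200-fold higher number from compound 3 to compound 4 (3.10 log units; beyond the scatter). Among the compounds shown here, this is the first direct reading of one change, as the earlier compounds differ only in how their methoxy groups are arranged. Compound 3 gives only a limit, so the true step may be larger: the limit of < 0.03 h in this assay, at which 1 of the 4 values shown sits.

Only hydrogen and methoxy are shown at this place, so the effect of an amine, an ethoxy or a fluorine there remains open. Going by these compounds, whether the same change at another ring position would have a similar effect also remains open.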